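The source may report more compounds than this note shows. Statements on the series, on what has been measured and on what is new or still open speak of the compounds shown alone.

Series notes. Compound 1 `O=C(NCCCCc1ccccc1)c1cccc(C2SCC(=O)N2c2cccc(-c3c[nH]nn3)c2)c1` carries a 1H-1,2,3-triazol-4-yl on the aromatic ring attached to the core nitrogen. In a functional assay on HOS-TE85 cells (Homo sapiens) for inhibition, read by CCK-8 assay, with a stated time of 72 h (a higher number here means a weaker inhibitor, a lower number a stronger inhibitor), compound 1 gives 110 nM, the highest number among the three measured compounds. Compound 2 `COc1ccccc1N1C(=O)C(C)SC1c1cccc(C(=O)NCCCCc2ccccc2)c1`, with a methoxy on that ring and a methyl on the core, gives 45.1 nM in this assay. Compound 3 `C#Cc1cc(C(=O)NCCCCc2ccccc2)cc(C2SCC(=O)N2c2ccccc2OC)c1`, also methoxy-substituted on that ring and bearing an ethynyl on the benzamide ring, gives 40.8 nM in this assay. Both numbers sit below that of compound 1 by more than the usual scatter.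

Compound 4 `Cc1cccc(N2C(=O)CSC2c2cccc(C(=O)NCCCCc3ccccc3)c2)c1` has not yet been measured. It differs from compound 1 in one place: methyl in place of 1H-1,2,3-triazol-4-yl on an aromatic carbon. Among the compounds with values here, no single-change pair among the measured compounds covers this replacement, so only the general trend that smaller substituents on this ring go with lower numbers (compounds 2 and 3) can be drawn on. A modest drop is expected, a 1.8-fold lower number from compound 1 to compound 4 (0.26 log units; within the scatter), with a range wide enough to include no change. For compound 4 in this assay the estimate is 60 nM, between 25 nM and 150 nM.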

Compound 4, half-maximal inhibitory concentration in the HOS-TE85 assay: 93.2 nM
The estimate for compound 4 lay 1.6-fold (0.19 log units) below the measured number; measured number inside the range.
By their numbers in the HOS-TE85 assay, from the lowest: compounds 3 and 2 (each within the scatter of the next); then compounds 4 and 1 (each within the scatter of the next).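

Within the data shown here, in the HOS-TE85 assay the replacement at this aromatic carbon gives a 1.2-fold lower number from compound 1 to compound 4 (0.07 log units; within the scatter), the first single-place step, so a methyl and a 1H-1,2,3-triazol-4-yl are not separated by this read-out. In a physicochemical assay for solubility, read by turbidimetry, measured as kinetic solubility, at pH 7.4 (on this read-out higher numbers stand for higher solubility and lower numbers for lower solubility), compound 1 gives 20000 nM and compound 4 gives 10000 nM, a step of a 2.0-fold lower number from compound 1 to compound 4 (0.30 log units; within the scatter), so here too the two are not separated. Nothing on hand accounts for either result.

Open, as far as these compounds go, is whether a carboxylic acid, an amine or a longer chain on this aromatic carbon would also leave both read-outs in place. From the compounds shown here alone, how the methoxy of compound 2 and compound 3 bears on the number also stays open: neither differs from compound 4 in one place only.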